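Iodo in place of tert-butyl: working notes

The source may hold more compounds than are shown below. What is called first, only, known or untested is meant among the compounds shown, and "the series" means these compounds.

Compound 1 `O=C(CCl)NC(=O)Nc1ccc(-c2ccccc2)cc1`: 2300 nM
Compound 2 `CC(C)(C)c1ccc(NC(=O)NC(=O)CCl)cc1`: 3300 nM

Going by the values given here, in a functional assay on HT-29 cells (Homo sapiens) for inhibition, read by sulforhodamine B assay, with a stated time of 48 h (a lower number here means a stronger inhibitor of growth, a higher number a weaker inhibitor of growth), compound 2 at 3300 nM stands within the scatter of compound 1, the only other measured compound. The next change is iodo in place of tert-butyl on an aromatic carbon, giving compound 3 `O=C(CCl)NC(=O)Nc1ccc(I)cc1`. Among the compounds with values here, one measured step bears on it, tert-butyl in place of phenyl on an aromatic carbon, which gave a 1.4-fold higher number from compound 1 to compound 2 (0.16 log units; within the scatter). Within the data shown here, no iodo compound has been measured, so this evidence is thin, and no step beyond the scatter is expected. The expected change is a 1.1-fold lower number from compound 2 to compound 3 (0.04 log units; within the scatter). For compound 3 the estimated value is 3000 nM, with an expected range of 1300 nM to 7000 nM.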

Compound 3, concentration for 50% growth inhibition: 6900 nM
Compound 3: middle estimate off by 2.3-fold (0.36 log units), on the low side, within the range that was stated.
By their numbers in this assay, from the lowest: compounds 1 and 2 (each within the scatter of the next); then compound 3.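

In this assay this aromatic carbon proves sensitive to its substituent: iodo in place of tert-butyl gives a 2.1-fold higher number from compound 2 to compound 3 (0.32 log units; beyond the scatter) and iodo in place of phenyl gives a 3.0-fold higher number from compound 1 to compound 3 (0.48 log units; beyond the scatter) in a series where phenyl and tert-butyl had stayed within the scatter of each other. Among these three compounds, iodo is therefore the one group that separates from the others, and the direction is towards weaker growth inhibition. No measurement on hand accounts for either step. Open, from the compounds shown here alone, is how an amine, a carboxylic acid or a methoxy group on this carbon would stand against iodo and tert-butyl in this assay.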